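Moving the Fluorine on an Anilide Series

A few compounds are considered here, and "the series" means these few. Any claim that something is new, unique, unknown or untested is made for them only; others in the source may bear on it.

Among the measured compounds shown here, compound 1 `CC1=C(/C=C/C(C)=C/C=C/C(C)=C\C(=O)Nc2ccc(F)cc2)C(C)(C)CCC1n1ccnc1` stands at the top of the three numbers measured so far: in a functional assay on CWR22R cells (Homo sapiens) for inhibition, read by MTT assay (a higher number here means a weaker inhibitor of growth, a lower number a stronger inhibitor of growth), compound 1 gives 8120 nM. Compound 2 `CC1=C(/C=C/C(C)=C/C=C/C(C)=C\C(=O)NCc2ccc(O)cc2)C(C)(C)CCC1n1ccnc1` gives 1860 nM, and compound 3 `CC1=C(/C=C/C(C)=C/C=C/C(C)=C\C(=O)Nc2ccccc2)C(C)(C)CCC1n1ccnc1` gives 1280 nM. The steps from compound 1 are a 4.4-fold lower number from compound 1 to compound 2 (0.64 log units; beyond the scatter) and a 6.3-fold lower number from compound 1 to compound 3 (0.80 log units; beyond the scatter), while between the other two a 1.5-fold lower number from compound 2 to compound 3 (0.16 log units; within the scatter). Compound 4 `CC1=C(/C=C/C(C)=C/C=C/C(C)=C\C(=O)Nc2cccc(F)c2)C(C)(C)CCC1n1ccnc1` differs from compound 1 by 3-fluorophenyl in place of 4-fluorophenyl on an amide-type nitrogen. For the measured compounds named here, the step bearing most on this is a 6.3-fold lower number from compound 1 to compound 3 (0.80 log units; beyond the scatter), which shows compound 1 with its 4-fluorophenyl to be the weakest inhibitor of the three; no measured step moves the fluoro rather than removing it. A modest lowering of the number is therefore expected, a 2.5-fold lower number from compound 1 to compound 4 (0.40 log units; beyond the scatter), though a step within the scatter cannot be excluded. Compound 4 is estimated at 3200 nM, within a range of 1000 nM to 10000 nM.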

Compound 4, concentration for 50% growth inhibition: 2040 nM
The estimate for compound 4 lay 1.6-fold (0.20 log units) above the measured number; the measured number falls inside the stated range.
By their numbers in this assay, from the lowest: compounds 3, 2 and 4 (each within the scatter of the next); then compound 1.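

Moving the fluoro matters in this assay: 3-fluorophenyl in place of 4-fluorophenyl gives a 4.0-fold lower number from compound 1 to compound 4 (0.60 log units; beyond the scatter), so the high number of compound 1 goes with 4-fluorophenyl, not with every fluorophenyl on this amide-type nitrogen. Fluoro in place of hydrogen now gives a 1.6-fold higher number from compound 3 to compound 4 (0.20 log units; within the scatter), and 3-fluorophenyl in place of 4-hydroxybenzyl gives a 1.1-fold higher number from compound 2 to compound 4 (0.04 log units; within the scatter), so neither change separates these compounds. Nothing at hand accounts for the effect of moving the fluoro. From the compounds shown here alone, how chlorophenyl or methoxyphenyl on the same nitrogen would compare remains open.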